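The compounds below may be only part of what the source reports. "The series", "measured", "known", "first", "only" and "open" are said of these compounds alone.

Of the compounds shown here, three sharing one core have been tested in a functional assay on HL-60 cells (Homo sapiens) for antiproliferative activity, read by MTT assay, with a stated time of 72 h (a lower number here means a stronger inhibitor, a higher number a weaker inhibitor), and none has yet given a number. Compound 1 (`COc1cccc(-c2ncnn2-c2cc(OC)c(OC)c(OC)c2)c1`) shows > 10000 nM as its result, which is a limit of the assay and not a number. Compound 2 (`COc1cc(-n2ncnc2-c2ccc(Cl)c(Cl)c2)cc(OC)c1OC`) shows > 10000 nM as its result, again a limit. On these data alone, compound 3 (`COc1cc(-n2ncnc2-c2cccc([N+](=O)[O-])c2)cc(OC)c1OC`) shows > 10000 nM as its result, also a limit, so its true place on the scale is unknown.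

Compound 4 (`COc1cc(-n2ncnc2-c2cccc(F)c2)cc(OC)c1OC`) has fluoro in place of nitro on an aromatic carbon, meta to a large group, and fluoro in place of nitro on an aromatic carbon gives the full count of that change. Among the measured compounds shown here, two measured steps bear on it. One is a step that the two limits leave unreadable from compound 1 to compound 3 (nitro in place of methoxy) and the other is a step that the two limits leave unreadable from compound 1 to compound 2 (3,4-dichlorophenyl in place of 3-methoxyphenyl), and neither has a size that can be read. For the measured compounds named here, compound 3 therefore offers only the limit of > 10000 nM in this assay, at which 3 of the 3 values shown sit, as a guide, and no compound here goes against it. No clear step up or down is expected in this assay for this change. The estimated change is a step that the limit leaves unreadable from compound 3 to compound 4 and it is expected to carry no firm direction. For compound 4 the estimate is 12000 nM with an expected range of 3000 nM to 40000 nM and a limit rather than a number is the likeliest result.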

Compound 4, half-maximal inhibitory concentration: > 10000 nM
Compound 4: a limit, no number; the forecaster's own chance of this, stated with the estimate: 85%; the middle value lies beyond the limit too.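

In this assay compound 4 gives > 10000 nM as its result, which is a limit of the assay and not a number. The steps to compound 4 from compound 1, compound 2 and compound 3 cannot be read. The compounds shown leave open which change to the shared core, if any, would give a measurable number in this test.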